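Removing the protecting group from compound 2

A few compounds are considered here, and "the series" means these few. Any claim that something is new, unique, unknown or untested is made for them only; others in the source may bear on it.

Compound 1 `C[C@H](NC(=O)c1cc(Cl)ccc1OCCNC(=O)OC(C)(C)C)C(=O)Nc1ccc([N+](=O)[O-])cc1Cl`: > 10000 nM
Compound 2 `CC(C)(C)OC[C@@H](NC(=O)c1cc(Cl)ccc1OCCNC(=O)OC(C)(C)C)C(=O)Nc1ccc([N+](=O)[O-])cc1Cl`: > 10000 nM
Compound 3 `CC(C)(C)OC[C@@H](NC(=O)c1cc(Cl)ccc1OCCN)C(=O)Nc1ccc([N+](=O)[O-])cc1Cl`: not yet measured

Both measured compounds were tested in a functional assay on MDA-MB-231 cells (Homo sapiens) for inhibition, read by MTT assay, with a stated time of 72 h; a lower number here means a stronger inhibitor, a higher number a weaker inhibitor. Compound 1 gives > 10000 nM, which is a limit of the assay and not a number. Compound 2 also gives only a limit, > 10000 nM. Compound 2 therefore stands with compound 1 at a shared ceiling: the limit of > 10000 nM in this assay, at which 2 of the 2 values shown sit. No exact potency is known for either compound.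

Compound 3 differs from compound 2 in one place, with hydrogen in place of tert-butoxycarbonyl on an amine nitrogen. The rest of the structure stays the same.

For the measured compounds named here, no measured pair shows what this change does in this assay, so the expectation is a judgement rather than a reading from a trend. A step toward stronger inhibition, larger than the usual scatter, is expected, although a result at the limit again would be no surprise. The expected change is an at least 2.5-fold lower number from compound 2 to compound 3 (0.39 log units; beyond the scatter). For compound 3 the estimated value is 4000 nM, with an expected range of 800 nM to 10000 nM.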

Compound 3, half-maximal inhibitory concentration: 3220 nM
Compound 3: the middle estimate sits 1.2-fold (0.09 log units) above what was measured; low and high end bracket the measured number.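

Among the three compounds shown, compound 3 alone gives an exact number in this assay, so this amine nitrogen is the first place in the series where a change is seen to move the result off the ceiling. Replacing tert-butoxycarbonyl with hydrogen, which removes a group of 7 heavy atoms and leaves a 2-aminoethyl chain, gives an at least 3.1-fold lower number from compound 2 to compound 3 (0.49 log units; beyond the scatter); compound 2 has only a limit, so this size is a minimum and the true gap could be larger. The other two compounds stay at the ceiling, which compound 3 has left: the limit of > 10000 nM in this assay, at which 2 of the 3 values shown sit.

The compounds shown leave open whether the gain comes from the free amine itself or simply from the loss of the tert-butoxycarbonyl group, a question that an acetyl or methyl group on the same nitrogen, or a longer chain carrying the amine, could help to answer. Also open, as far as these compounds go, is how much the tert-butyl ether, still present in compound 3, contributes to the result, which a free hydroxyl in its place could test.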